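From cyclopropyl to vinyl on a four-membered ring

The source may report more compounds than this note shows. Statements on the series, on what has been measured and on what is new or still open speak of the compounds shown alone.

In a functional assay on HL-60 cells (Homo sapiens) for inhibition, read by resazurin assay, with a stated time of 72 h (a higher number here means a weaker inhibitor, a lower number a stronger inhibitor), compound 1 `COc1ccc(C2C(Oc3ccccc3)C(=O)N2c2cc(OC)c(OC)c(OC)c2)cc1` gives 19 nM, while compound 2 `COc1ccc(C2C(C3CC3)C(=O)N2c2cc(OC)c(OC)c(OC)c2)cc1` gives 156 nM, the higher of the two numbers. Compound 3 `C=CC1C(=O)N(c2cc(OC)c(OC)c(OC)c2)C1c1ccc(OC)cc1` carries vinyl in place of cyclopropyl on a saturated ring carbon. Among the measured compounds shown here, only one measured step bears on this place: an 8.2-fold higher number from compound 1 to compound 2 (0.91 log units; beyond the scatter), modest and beyond the scatter. A smaller step toward a lower number is therefore expected in this assay, though one step is thin support. The estimated step is a 2.2-fold lower number from compound 2 to compound 3 (0.35 log units; beyond the scatter). Compound 3 is expected at 70 nM, with an estimated range of 20 nM to 220 nM.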

Compound 3, half-maximal inhibitory concentration: 33 nM
Estimate against measurement, compound 3: 2.1-fold (0.33 log units) above; the measured number falls inside the stated range.
By their numbers in this assay, from the lowest: compounds 1 and 3 (each within the scatter of the next); then compound 2.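

In this assay this saturated ring carbon does not need a large group such as phenoxy to give a low number: the change to vinyl gives a 1.7-fold higher number from compound 1 to compound 3 (0.24 log units; within the scatter) and so stays level with phenoxy. Replacing cyclopropyl with vinyl at the same place gives a 4.7-fold lower number from compound 2 to compound 3 (0.67 log units; beyond the scatter) and separates two small carbon groups. Nothing available explains this difference.

The compounds shown cannot separate the double bond of vinyl from the loss of the three-membered ring. Going by these compounds, how an ethyl group, a longer chain or an amine would behave at this place remains open.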